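Replacing Methoxyphenyl with Trifluoromethylphenyl on the Shared Core

The source may report more compounds than this note shows. Statements on the series, on what has been measured and on what is new or still open speak of the compounds shown alone.

Compound 1 `Brc1cn2ccnc2c(-c2ccc3ncn(C4CCCCC4)c3c2)n1`: 17.2%
Compound 2 `COc1ccc(-c2cn3ccnc3c(-c3ccc4ncn(C5CCCCC5)c4c3)n2)cc1`: 95.2%
Compound 3 `Fc1ccc(-c2cn3ccnc3c(-c3ccc4ncn(C5CCCCC5)c4c3)n2)cc1`: 53.6%

Of the compounds shown here, three sharing one core have been measured in a functional assay on PC-3 cells (Homo sapiens) for inhibition, read by sulforhodamine B assay, with a stated time of 48 h, tested at 10 uM; a lower number here means less inhibition, a higher number more inhibition at the concentration tested (going by the name of the read-out). Compound 2 stands highest of the three; compound 3 is nearest, with a number 41.6 percentage points lower from compound 2 to compound 3 (beyond the scatter), and compound 1 is furthest, with a number 78 percentage points higher from compound 1 to compound 2 (beyond the scatter). Compound 3 likewise sits well above compound 1, with a number 36.4 percentage points higher from compound 1 to compound 3 (beyond the scatter).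

Compound 4 `FC(F)(F)c1cccc(-c2cn3ccnc3c(-c3ccc4ncn(C5CCCCC5)c4c3)n2)c1` has not been measured. Its change from compound 2 is 3-(trifluoromethyl)phenyl in place of 4-methoxyphenyl on an aromatic carbon. Going by the values given here, two measured steps bear on it: both aryl groups in place of bromo gave a much higher number in this assay, while the swap of methoxy for fluoro gave a much lower one. Among the compounds with values here, a trifluoromethyl at a different ring position has no direct precedent here, so the expected step is a drop from compound 2, of uncertain size: a number 40.2 percentage points lower from compound 2 to compound 4 (beyond the scatter). Compound 4 is therefore estimated at 55%, with a range from 25% to 85%.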

Compound 4, a percentage reported as inhibition, at one concentration (the size of the read-out at that concentration, not a potency): 36.5%
Estimate against measurement, compound 4: 18.5 percentage points above; the measured number falls inside the stated range.
By their numbers in this assay, from the lowest: compound 1; then compound 4; then compound 3; then compound 2.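

In this assay a third aryl group in place of bromo again raises the number, with a number 19.3 percentage points higher from compound 1 to compound 4 (beyond the scatter) as the step, so all three aryl groups shown stand above the bromo compound. The choice of aryl group matters greatly, with a number 58.7 percentage points lower from compound 2 to compound 4 (beyond the scatter) and with a number 17.1 percentage points lower from compound 3 to compound 4 (beyond the scatter) as well, which puts 3-(trifluoromethyl)phenyl lowest of the three aryl groups. No measurement shown here accounts for this order.

The step from 4-methoxyphenyl to 3-(trifluoromethyl)phenyl changes both the group on the phenyl ring and its place on that ring, so the shown compounds cannot separate the two contributions. Going by these compounds, how an amine or a carboxylic acid on the phenyl ring would behave at this position also remains open.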